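The source may report more compounds than this note shows. Statements on the series, on what has been measured and on what is new or still open speak of the compounds shown alone.

Working notes on the series

Within the data shown here, compound 1, `O=C(Nc1cc(C(F)(F)F)cc(C(F)(F)F)c1)c1cc(Br)ccc1O`, is one of two members measured so far in a functional assay on Jurkat cells (Homo sapiens) for cytotoxicity, read by luminescence and CellTiter-Glo, with a stated time of 3 days (on this read-out lower numbers stand for stronger inhibition and higher numbers for weaker inhibition), where compound 1 gives 350 nM. Among the measured compounds shown here, its only neighbour is compound 2, `O=C(Nc1cc(C(F)(F)F)cc(C(F)(F)F)c1)c1ccc(Cl)cc1O`, which in this assay gives 570 nM. For the measured compounds named here, the single step available, a 1.6-fold higher number from compound 1 to compound 2 (0.21 log units; within the scatter), is within the scatter, so the two numbers cannot be told apart and compound 1 stands in the same range as compound 2 rather than apart from it.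

Compound 3, `O=C(Nc1cc(C(F)(F)F)cc(C(F)(F)F)c1)c1cc(Br)c(F)cc1O`, has not been measured. Relative to compound 1 the change is fluoro in place of hydrogen on an aromatic carbon: the entering fluoro sits on an aromatic carbon of the six-membered aromatic ring of carbon only, ortho to the bromo group, meta to the hydroxy group and para to a large group.

Going by the values given here, no measured step adds a fluoro to this ring; the one step seen, from compound 1 to compound 2, concerns a different change and was within the scatter. Among the compounds with values here, with no bearing step, a step within the scatter is expected for compound 3, no change at the digits printed from compound 1 to compound 3 (within the scatter), in no particular direction. Compound 3 is therefore estimated at 350 nM in this assay, with a range from 150 nM to 800 nM.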

Compound 3, half-maximal inhibitory concentration: 700 nM
Estimate against measurement, compound 3: 2.0-fold (0.30 log units) below; low and high end bracket the measured number.
By their numbers in this assay, from the lowest: compounds 1, 2 and 3 (each within the scatter of the next).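

In this assay, fluoro in place of hydrogen on an aromatic carbon, ortho to a bromo group, meta to a hydroxy group and para to a large group, gives a 2.0-fold higher number from compound 1 to compound 3 (0.30 log units; within the scatter), so the number stays within the scatter with a fluoro at this position. Among these compounds, this is the first measured step at this position of the ring; the earlier step concerned a different change and could say nothing about this place. The reading covers one atom at one place only, and nothing at hand bears on why the number for compound 3 stands where it does.

From the compounds shown here alone, whether a larger or differently built group at this position, such as a methoxy group, an amine or a carboxylic acid, would also keep the number in the same range remains open. Equally open, going by these compounds, is whether fluoro at this position would give a similar reading with a chloro group in place of the bromo group, or with the hydroxy group replaced by an amine.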